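The compounds below may be only part of what the source reports. "The series", "measured", "known", "first", "only" and "open" are said of these compounds alone.

Three anilides were tested in an ADME assay on RAW264.7 cells (Mus musculus) for cytotoxicity, read by MTT assay, with a stated time of 48 h; on this read-out lower numbers stand for stronger inhibition and higher numbers for weaker inhibition. Compound 1 `COc1cc(NC(=O)c2ccc(Cl)cc2)ccc1NS(C)(=O)=O` gives 70000 nM, compound 2 `COc1cc(NC(=O)c2cccc(C(F)(F)F)c2)ccc1NS(C)(=O)=O` gives 84800 nM, and compound 3 `CS(=O)(=O)Nc1ccc(NC(=O)c2ccc(Cl)cc2)cc1Cl` gives 79900 nM. Compound 3 arises from compound 1 by one change, (chloro in place of methoxy on an aromatic carbon), and the step of a 1.1-fold higher number from compound 1 to compound 3 (0.06 log units; within the scatter) stays within the scatter. The cores of compound 1 and compound 2 differ in a way that is not broken down here. Compound 4 `CS(=O)(=O)Nc1ccc(NC(=O)c2cccc(C(F)(F)F)c2)cc1Cl` stands to compound 2 as compound 3 stands to compound 1, by chloro in place of methoxy on an aromatic carbon, the same change at the same kind of place. Because a 1.1-fold higher number from compound 1 to compound 3 (0.06 log units; within the scatter) was flat, the step from compound 2 to compound 4 is expected to be a 1.1-fold higher number from compound 2 to compound 4 (0.03 log units; within the scatter), likewise flat. Compound 4 is therefore estimated at 90000 nM, expected between 50000 nM and 160000 nM.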

Compound 4, half-maximal inhibitory concentration: > 250000 nM
Compound 4: no number, only a limit (the forecaster's own chance of this, stated with the estimate: 15%); middle value at least 2.7-fold (0.44 log units) from the limit.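

In this assay compound 4 gives > 250000 nM, which is a limit of the assay and not a number. On this core, chloro in place of methoxy on an aromatic carbon gives an at least 2.9-fold higher number from compound 2 to compound 4 (0.46 log units; beyond the scatter), so the change did not stay flat here as it did on the core of compound 1. This does not show by how much the change moves the read-out on this core, nor that the two steps truly differ: the same change on two cores in this assay, a 1.1-fold higher number (0.06 log units; within the scatter) from compound 1 to compound 3 and an at least 2.9-fold higher number (0.46 log units; beyond the scatter) from compound 2 to compound 4; the limit leaves it open whether they differ

The compounds shown leave open how the same change would read with an amine or a carboxylic acid in place of the trifluoromethyl group. They also leave open whether a methyl or a bromo group in place of methoxy would read as chloro does.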